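Thiosemicarbazone Aryl Substitution Under Scrutiny

A few compounds are considered here, and "the series" means these few. Any claim that something is new, unique, unknown or untested is made for them only; others in the source may bear on it.

Compound 1 `NC(=S)N/N=C/c1ccc2ccccc2n1` is the parent thiosemicarbazone. In a functional assay on SGC-7901 cells (Homo sapiens) for antiproliferative activity, read by sulforhodamine B assay, with a stated time of 72 h (on this read-out lower numbers stand for stronger inhibition and higher numbers for weaker inhibition), compound 1 gives 32700 nM. Compound 2 `CC(C)c1cccc(C(C)C)c1NC(=S)N/N=C/c1ccc2ccccc2n1` carries a bulky aryl group on the same nitrogen, and in this assay compound 2 gives 23500 nM, a number that lies within the usual scatter of that for compound 1. Compound 3 `S=C(N/N=C/c1ccc2ccccc2n1)Nc1ccc(Cl)cc1` is the next analogue: 4-chlorophenyl in place of hydrogen on an amide-type nitrogen. Because compound 2 with its aryl substituent gave 23500 nM, no step beyond the scatter is expected, with at most a slight lowering; the expected step is a 1.5-fold lower number from compound 1 to compound 3 (0.17 log units; within the scatter). Compound 3 is estimated at 22000 nM, within 7000 nM to 60000 nM.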

Compound 3, half-maximal inhibitory concentration: 87600 nM
Compound 3: the middle estimate sits 4.0-fold (0.60 log units) below what was measured, outside the stated range (above it).
By their numbers in this assay, from the lowest: compounds 2 and 1 (each within the scatter of the next); then compound 3.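

In this assay, placing 4-chlorophenyl on the amide-type nitrogen gives a 2.7-fold higher number from compound 1 to compound 3 (0.43 log units; beyond the scatter) and so a modest weakening. This shows that an aryl substituent at this position is not always tolerated without change, something compound 2 at 23500 nM had not revealed. Nothing presented here accounts for the weakening. The compounds shown leave open whether the step belongs to the phenyl ring or to its chlorine, a question that plain phenyl would address. As far as these compounds go, how a methyl group or a morpholine ring would fare on this nitrogen also remains open.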